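Cyclohexyl to Pyridin-2-yl on the Amide Nitrogen

The compounds below may be only part of what the source reports. "The series", "measured", "known", "first", "only" and "open" are said of these compounds alone.

Compound 1, `C#CCn1cc(C(=O)NC(CC(=O)Nc2ccccc2)c2ccccc2)c(=O)c2cc(F)c(Cl)nc21`, 6900 nM in a functional assay on MIA PaCa-2 cells (Homo sapiens) for cytotoxicity, read by MTT assay, with a stated time of 72 h; on this read-out lower numbers stand for stronger inhibition and higher numbers for weaker inhibition
Compound 2, `C#CCn1cc(C(=O)NC(CC(=O)Nc2ccccn2)c2ccccc2)c(=O)c2ccc(Cl)nc21`, > 10000 nM in this assay, a limit
Compound 3, `C#CCn1cc(C(=O)NC(CC(=O)NC2CCCCC2)c2ccccc2)c(=O)c2cc(F)c(Cl)nc21`, 4900 nM in this assay

Compound 3 gives the lowest of the two actual numbers measured in this assay, though its neighbour compound 1 sits within the scatter of it: a 1.4-fold lower number from compound 1 to compound 3 (0.15 log units; within the scatter). Compound 2 returned only a limit, (the limit of > 10000 nM in this assay, at which 1 of the 3 values shown sits), so no number exists for it.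

Compound 4, `C#CCn1cc(C(=O)NC(CC(=O)Nc2ccccn2)c2ccccc2)c(=O)c2cc(F)c(Cl)nc21`, has not been measured. It differs from compound 3 in one place: pyridin-2-yl in place of cyclohexyl on an amide-type nitrogen. For the measured compounds named here, only one measured step bears on this position, the exchange of phenyl for cyclohexyl between compound 1 and compound 3, and it changed nothing beyond the scatter. Compound 2 also carries a (pyridin-2-yl)carbamoyl group, though on a core without the fluorine, and it gave only a limit in this assay. That gives some reason to expect a weaker or unmeasurable result for compound 4, but nothing tells how much the fluorine matters.

Compound 4 is therefore expected to give about 8000 nM in this assay, with a range from 3000 nM to 20000 nM. The expected step of a 1.6-fold higher number from compound 3 to compound 4 (0.21 log units; within the scatter) is modest, toward a higher number, with a real chance that only a limit is reported.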

Compound 4, half-maximal inhibitory concentration: > 10000 nM
Compound 4 gave a limit, no number; the forecaster's own chance of this, stated with the estimate: 40%; at least 1.2-fold (0.09 log units) between middle value and limit.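

Placing pyridin-2-yl on the amide-type nitrogen gives an at least 2.0-fold higher number from compound 3 to compound 4 (0.30 log units; that floor lies within the scatter), and measured against the phenyl group it gives an at least 1.4-fold higher number from compound 1 to compound 4 (0.16 log units; that floor lies within the scatter); both are only floors, so neither step is shown to be a real change on its own. The earlier compounds shown here showed that cyclohexyl and phenyl stay within the scatter of each other at this position, while compound 4 adds that pyridin-2-yl on the fluoro-bearing core returns a limit and no number in this assay. Compound 2 and compound 4 differ only by fluoro in place of hydrogen on an aromatic carbon, yet the step between them cannot be read, and both pyridin-2-yl compounds end in the same place: the limit of > 10000 nM in this assay, at which 2 of the 4 values shown sit.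

The compounds shown leave open what actual number compound 4 would have and whether fluoro matters at all when pyridin-2-yl is present. They also leave open how a benzyl group, or a longer chain ending in an amine or a carboxylic acid, would read on the same amide-type nitrogen.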